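The source may report more compounds than this note shows. Statements on the series, on what has been measured and on what is new or still open speak of the compounds shown alone.

Working notes on the series. In a functional assay on HCT-116 cells (Homo sapiens) for antiproliferative activity, with a stated time of 72 h (on this read-out higher numbers stand for weaker inhibition and lower numbers for stronger inhibition), compound 1 `Nc1ccc(-c2ccccc2)cc1NC(=O)c1ccc(CN2CCC3(CCCN3)CC2)cc1` gives 118 nM, compound 2 `Nc1ccc(-c2ccccc2F)cc1NC(=O)c1ccc(CN2CCC3(CCCN3)CC2)cc1` gives 470 nM and compound 3 `Nc1ccc(-c2cccs2)cc1NC(=O)c1ccc(C(=O)N2CCC3(CCCN3)CC2)cc1` gives 70 nM. Compound 3 lies within the scatter of compound 1, and the number for compound 2 is clearly higher than that of compound 3.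

The next structure is compound 4 `Nc1ccc(-c2ccccc2F)cc1NC(=O)c1ccc(C(=O)N2CCC3(CCCN3)CC2)cc1`: 2-fluorophenyl in place of thiophen-2-yl on an aromatic carbon, with 2-fluorophenyl in place of thiophen-2-yl on an aromatic carbon. Going by the values given here, the one measured step that bears on this change is a 4.0-fold higher number from compound 1 to compound 2 (0.60 log units; beyond the scatter), a modest step beyond the scatter for fluoro in place of hydrogen on an aromatic carbon. Among the compounds with values here, no measured pair compares thiophen-2-yl with phenyl directly. Compound 1 and compound 2 also carry a methylene link where compound 3 carries a carbonyl, so the transfer is uncertain. A modest rise of similar size is expected in this assay. The expected change is a 3.6-fold higher number from compound 3 to compound 4 (0.55 log units; beyond the scatter). For compound 4 the estimated value is 250 nM, with an expected range of 90 nM to 700 nM.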

Compound 4, half-maximal inhibitory concentration: 290 nM
Beside the measured number, compound 4's estimate is 1.2-fold (0.06 log units) below it; measured number inside the range.
By their numbers in this assay, from the lowest: compounds 3 and 1 (each within the scatter of the next); then compounds 4 and 2 (each within the scatter of the next).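

In this assay, thiophen-2-yl giving way to 2-fluorophenyl on the aromatic carbon para to an amino group produces a 4.1-fold higher number from compound 3 to compound 4 (0.62 log units; beyond the scatter) and shows that this position also responds in a compound with the carbonyl link, where the earlier step came from a pair with the methylene link. With 2-fluorophenyl held constant, compound 2 gives 470 nM and compound 4 gives 290 nM, values within the scatter of each other, so the two links are not separated in this aryl context. Nothing at hand explains the step.

The compounds shown leave open how a plain phenyl group on the carbonyl-linked core compares with thiophen-2-yl, and so how much of the step belongs to the fluoro group. From the compounds shown here alone, how a pyridyl ring or thiophen-3-yl would read at this position also remains open.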